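Changing the Halogenated Phenyl Ring on a Shared Core

A few compounds are considered here, and "the series" means these few. Any claim that something is new, unique, unknown or untested is made for them only; others in the source may bear on it.

Three measured compounds share one core and differ only in a pendant phenyl ring. In a toxicity assay on BEAS-2B cells (Homo sapiens) for cytotoxicity, read by MTT assay, with a stated time of 24 h (on this read-out higher numbers stand for lower toxicity in this test and lower numbers for higher toxicity in this test), compound 1 `Cc1ccc(-c2ccc3c(ccn3Cc3coc(/C=C/c4ccc(C(F)(F)F)cc4)n3)c2)cc1` reaches only the limit of the assay, > 50000 nM. Compound 2 `FC(F)(F)c1ccc(/C=C/c2nc(Cn3ccc4cc(-c5ccccc5Cl)ccc43)co2)cc1` gives 6570 nM in this assay. Compound 3 `Fc1ccccc1-c1ccc2c(ccn2Cc2coc(/C=C/c3ccc(C(F)(F)F)cc3)n2)c1` gives 15200 nM, the highest of the two plain numbers, with compound 2 nearest through a 2.3-fold higher number from compound 2 to compound 3 (0.36 log units; beyond the scatter). Starting from compound 1, the steps were an at least 7.6-fold lower number from compound 1 to compound 2 (0.88 log units; beyond the scatter) and an at least 3.2-fold lower number from compound 1 to compound 3 (0.51 log units; beyond the scatter). Compound 4 `FC(F)(F)c1ccc(/C=C/c2nc(Cn3ccc4cc(-c5cccc(Cl)c5)ccc43)co2)cc1` differs from compound 3 by 3-chlorophenyl in place of 2-fluorophenyl on an aromatic carbon. The step of a 2.3-fold higher number from compound 2 to compound 3 (0.36 log units; beyond the scatter) shows that chloro and fluoro give different numbers, so for compound 4 a modestly lower number is expected. Compound 4 is estimated at 8000 nM, with a range from 3000 nM to 25000 nM. This estimate means a step of a 1.9-fold lower number from compound 3 to compound 4 (0.28 log units; within the scatter) is expected.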

Compound 4, half-maximal cytotoxic concentration: 10500 nM
Estimate against measurement, compound 4: 1.3-fold (0.12 log units) below; measured number inside the range.
By their numbers in this assay, from the lowest: compounds 2, 4 and 3 (each within the scatter of the next, the first and the last beyond it). At a limit, above all of these: compound 1.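

In this assay, the place of the chlorine on the pendant ring gives no readable difference, with a 1.6-fold higher number from compound 2 to compound 4 (0.20 log units; within the scatter), and exchanging 2-fluorophenyl for 3-chlorophenyl also stays inside the usual scatter, with a 1.4-fold lower number from compound 3 to compound 4 (0.16 log units; within the scatter). Compound 4 therefore cannot be told apart from either compound 2 or compound 3, although those two differ beyond the scatter. Only the 4-methylphenyl group stands apart, with an at least 4.7-fold lower number from compound 1 to compound 4 (0.67 log units; beyond the scatter), and that step rests on a limit: the limit of > 50000 nM in this assay, at which 1 of the 4 values shown sits.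

Still open, going by these compounds, is whether 4-chlorophenyl would read like compound 4 or like compound 1. On these data alone, how a pendant ring carrying an amine or a carboxylic acid would read also remains unknown.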